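From benzyl to 4-bromophenyl on the ring nitrogen

The source may report more compounds than this note shows. Statements on the series, on what has been measured and on what is new or still open speak of the compounds shown alone.

Measured so far:
Compound 1 `COc1cc(-c2nccn2C(C)C)cc(OC)c1OC` gives > 100000 nM as a limit
Compound 2 `COc1cc(-c2nccn2Cc2ccccc2)cc(OC)c1OC` gives > 100000 nM as a limit
Compound 3 `COc1cc(OC)cc(-n2ccnc2-c2cc(OC)c(OC)c(OC)c2)c1` gives 57500 nM as a true number

In a functional assay on MDA-MB-468 cells (Homo sapiens) for antiproliferative activity, read by MTT assay, with a stated time of 72 h (on this read-out higher numbers stand for weaker inhibition and lower numbers for stronger inhibition), compound 2 gives no true number, only a limit. From the compounds shown here alone, compound 2 sits at the limit of > 100000 nM in this assay, at which 2 of the 3 values shown sit, and its real strength stays unknown.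

Compound 4 `COc1cc(-c2nccn2-c2ccc(Br)cc2)cc(OC)c1OC` has 4-bromophenyl in place of benzyl on an aromatic nitrogen while the shared core stays the same. Within the data shown here, the one measured step at this nitrogen is a step that the two limits leave unreadable from compound 1 to compound 2 and it offers no size to carry over. Compound 3 is a better guide, since it also has an aromatic ring directly on that nitrogen, and compound 3 gives 57500 nM as a true number. That suggests a modest move towards stronger inhibition, though another reading at the limit remains quite possible. The estimated change is an at least 2.0-fold lower number from compound 2 to compound 4 (0.30 log units; that floor lies within the scatter) towards lower numbers. For compound 4 the estimated value in this assay is 50000 nM with an expected range from 10000 nM to 100000 nM overall.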

Compound 4, half-maximal inhibitory concentration: 2700 nM
Beside the measured number, compound 4's estimate is 19-fold (1.27 log units) above it, and the stated range ends above it.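

In this assay, putting 4-bromophenyl on this nitrogen gives an at least 37-fold lower number from compound 2 to compound 4 (1.56 log units; beyond the scatter), and the same group gives an at least 37-fold lower number from compound 1 to compound 4 (1.56 log units; beyond the scatter), so the group here can move the read-out a long way. Compound 3 also has an aromatic ring directly on that nitrogen, yet compound 3 gives 57500 nM while compound 4 gives 2700 nM, so a ring at this place does not by itself bring the low number. The true size of both steps stays unknown, because each starts from a limit rather than a measured number: the limit of > 100000 nM in this assay, at which 2 of the 4 values shown sit.

The compounds shown leave open whether the bromine matters or the directly attached ring alone accounts for the step. A plain phenyl ring, or a ring bearing an amine or a carboxylic acid in place of bromine, would separate these readings.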